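Ethoxycarbonyl to acetyl: expected growth inhibition of compound 4

The compounds below may be only part of what the source reports. "The series", "measured", "known", "first", "only" and "open" are said of these compounds alone.

For the measured compounds named here, the series shares the core of compound 1 `C=C(C)[C@@H]1CC=C(Cn2cc(COc3ccc(C4NC(=O)NC(C)=C4C(=O)OCC)cc3)nn2)CC1`, which in a functional assay on HT-29 cells (Homo sapiens) for inhibition, read by sulforhodamine B assay, with a stated time of 48 h (a higher number here means a weaker inhibitor of growth, a lower number a stronger inhibitor of growth), gives 77100 nM, the only plain number among the three values shown. Compound 2 `C=C(C)[C@@H]1CC=C(Cn2cc(COc3ccccc3C3NC(=O)NC(C)=C3C(=O)OCC)nn2)CC1` returns in this assay only the limit > 100000 nM. Compound 3 `C=C(C)[C@@H]1CC=C(Cn2cc(COc3ccc(C4NC(=O)NC(C)=C4C(=O)OCC)cc3OC)nn2)CC1` likewise returns in this assay the limit > 100000 nM. The step of an at least 1.2-fold higher number from compound 1 to compound 3 (0.11 log units; that floor lies within the scatter) therefore rests on a limit, and the limit of > 100000 nM in this assay, at which 2 of the 3 values shown sit, is the bound at which two of the three values sit.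

Compound 4 `C=C(C)[C@@H]1CC=C(Cn2cc(COc3ccc(C4NC(=O)NC(C)=C4C(C)=O)cc3)nn2)CC1` is not yet measured. It differs from compound 1 by methyl in place of ethoxy on a carbonyl carbon. Going by the values given here, no measured step touches this carbonyl carbon, and the one known step, methoxy in place of hydrogen on an aromatic carbon, gives no guide for it. With nothing pointing either way, the expected step of a 1.0-fold higher number from compound 1 to compound 4 (0.02 log units; within the scatter) is none beyond the scatter. Since two of the three values shown are limits, a limit for compound 4 is also a fair possibility. Compound 4 is therefore estimated at 80000 nM, with a range from 30000 nM to 250000 nM.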

Compound 4, concentration for total growth inhibition: 62600 nM
The estimate for compound 4 lay 1.3-fold (0.11 log units) above the measured number, and the stated range covers the measured number.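

In this assay, ethoxycarbonyl to acetyl gives a 1.2-fold lower number from compound 1 to compound 4 (0.09 log units; within the scatter), so at this carbonyl carbon, methyl can stand in place of ethoxy with no readable change in growth inhibition. For the compounds shown here, this is the first measured step at this position, and compound 4, at 62600 nM, returns a plain number rather than a limit. Little room remains in this assay for reading any loss of growth inhibition in the series: the limit of > 100000 nM in this assay, at which 2 of the 4 values shown sit.

Going by these compounds, whether a carboxylic acid, an amine-derived amide or a longer chain on this carbonyl carbon would move the number beyond the scatter stays open. Also open, on these data alone, is whether the acetyl group together with the methoxy group of compound 3 would return a plain number or a limit.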